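Xanthine series: imidazole nitrogen substituent, cyano to methoxy

A few compounds are considered here, and "the series" means these few. Any claim that something is new, unique, unknown or untested is made for them only; others in the source may bear on it.

Measured compounds:
compound 1 `CCCn1c(=O)n(CCOC)c(=O)c2[nH]cnc21` — 2500 nM
compound 2 `CCCn1c(=O)n(C)c(=O)c2c1ncn2CCC#N` — 88600 nM

Within the data shown here, in an assay on Cerebral cortex for binding affinity to adenosine receptor A1 (Cavia porcellus), read by radioligand binding (on this read-out higher numbers stand for weaker inhibition and lower numbers for stronger inhibition), compound 2 gives the higher of the two numbers, with compound 1 the only neighbour and far beyond the scatter below it. Among the measured compounds shown here, no single-point step connects compound 1 and compound 2. Compound 3 `CCCn1c(=O)n(C)c(=O)c2c1ncn2CCOC` is the unmeasured partner of compound 2; the change is methoxy in place of cyano on a saturated chain carbon, two bonds along the chain from an aromatic nitrogen. For the measured compounds named here, no comparable step is available among the measured pairs, so the size of the step is open. A modest decrease of the number is expected, a 2.5-fold lower number from compound 2 to compound 3 (0.40 log units; beyond the scatter), close to the scatter. Compound 3 is estimated at 35000 nM, range 9000 nM to 130000 nM.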

Compound 3, inhibition constant: 12400 nM
Compound 3: the middle estimate sits 2.8-fold (0.45 log units) above what was measured, and the stated range covers the measured number.
By their numbers in this assay, from the lowest: compound 1; then compound 3; then compound 2.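

In this assay, among these compounds, the change of methoxy in place of cyano on a saturated chain carbon, two bonds along the chain from an aromatic nitrogen, gives a 7.1-fold lower number from compound 2 to compound 3 (0.85 log units; beyond the scatter) as the first single-place comparison. This place is therefore not indifferent to the group it carries, even though the two groups match in heavy-atom and hydrogen-bond acceptor counts. Nothing available explains the size of this step. On these data alone, whether an amine, a carboxylic acid or a longer chain in the same place would lower the number further stays open.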